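A few compounds are considered here, and "the series" means these few. Any claim that something is new, unique, unknown or untested is made for them only; others in the source may bear on it.

Measured in an ADME assay on A549 cells (Homo sapiens) for cytotoxicity, read by resazurin assay, with a stated time of 48 h; on this read-out higher numbers stand for lower toxicity in this test and lower numbers for higher toxicity in this test:
- Compound 1 `CCCCCCC(C)Nc1ccc(NC(=O)c2cc(Cl)ccc2O)c(Cl)c1`: 23500 nM
- Compound 2 `O=C(Nc1ccc(NCc2cc(Cl)cc(Cl)c2)cc1Cl)c1cc(Cl)ccc1O`: 13300 nM

Within the data shown here, these are the only two measured compounds, and their values lie within the scatter of each other, so compound 2 sits level with compound 1 rather than clearly apart from it. The next compound, compound 3 `CC(C)(CCO)Nc1ccc(NC(=O)c2cc(Cl)ccc2O)c(Cl)c1`, has not yet been measured. It replaces the group on the nitrogen of compound 2: 3-hydroxy-1,1-dimethylpropyl in place of 3,5-dichlorobenzyl on a nitrogen on an aromatic ring.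

Among the measured compounds shown here, one measured step bears on this change. In a 1.8-fold lower number from compound 1 to compound 2 (0.25 log units; within the scatter), the same nitrogen changed its group and the value stayed within the scatter. Like 1-methylheptyl in compound 1, which gives 23500 nM, the entering group has no ring. For the measured compounds named here, no measured compound carries a hydroxyl-bearing chain, so the data leave that feature untested. In this assay, only a small shift toward a higher number is therefore expected, of about the size of the scatter. The expected change is a 1.9-fold higher number from compound 2 to compound 3 (0.27 log units; within the scatter). For compound 3, the estimated value is 25000 nM, with an expected range of 10000 nM to 60000 nM.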

Compound 3, half-maximal cytotoxic concentration: 170000 nM
For compound 3 the middle estimate is 6.8-fold (0.83 log units) below the measured one; measured number outside the range, above it.
By their numbers in this assay, from the lowest: compounds 2 and 1 (each within the scatter of the next); then compound 3.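

In this assay the group on this nitrogen can move the number well beyond the scatter, which the earlier step between 1-methylheptyl and 3,5-dichlorobenzyl did not show. Placing 3-hydroxy-1,1-dimethylpropyl there gives a 13-fold higher number from compound 2 to compound 3 (1.11 log units; beyond the scatter) and also a 7.2-fold higher number from compound 1 to compound 3 (0.86 log units; beyond the scatter), so compound 3 stands clearly apart from both earlier compounds, with the highest number and the lowest toxicity in this test of the three. The absence of a ring does not by itself go with this higher number, since the 1-methylheptyl group of compound 1 also has no ring, and nothing here gives a measured reason for the shift.

The hydroxyl and the two methyl groups enter together in compound 3, so the compounds shown do not separate what each contributes. They also leave open how the same branched chain would read in this assay with a methoxy group, an amine or a carboxylic acid at its end in place of the hydroxyl, and how a longer hydroxyl-bearing chain would read there.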